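Melatonin receptor type 1B series: benzyl to pyridin-2-yl ether

The compounds below may be only part of what the source reports. "The series", "measured", "known", "first", "only" and "open" are said of these compounds alone.

Measured so far in an assay on CHO cells for displacement of a labelled ligand from melatonin receptor type 1B (Homo sapiens), read by scintillation counting, with a stated time of 60 min; on this read-out higher numbers stand for weaker inhibition and lower numbers for stronger inhibition:
compound 1 `CCCC(=O)NCCCc1cc(OC)ccc1OCc1ccccc1` gives 0.00103 nM
compound 2 `CCCOc1ccc(OC)cc1CCCNC(C)=O` gives 2.12 nM
compound 3 `COc1ccc(OCCc2ccccc2)c(CCCNC(C)=O)c1` gives 13.4 nM

Compound 3 stands highest of the three; compound 2 sits nearest, compound 1 furthest by a very wide margin. Compound 4 `COc1ccc(OCc2ccccn2)c(CCCNC(C)=O)c1` differs from compound 3 by pyridin-2-yl in place of benzyl on a saturated chain carbon bound to an oxygen on an aromatic ring. The single step with a shown size, a 6.3-fold higher number from compound 2 to compound 3 (0.80 log units; beyond the scatter), swaps methyl for phenyl further out on the chain and is not the same change, so no directly comparable step exists. Compound 1, which carries a benzyl ether but also a different amide, gives a far lower number, and the pair is not a clean step. Compound 4 is therefore expected to sit somewhat below compound 3, by a 2.7-fold lower number from compound 3 to compound 4 (0.43 log units; beyond the scatter), at an estimated 5 nM within 0.5 nM to 50 nM.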

Compound 4, inhibition constant: 1.61 nM
Estimate against measurement, compound 4: 3.1-fold (0.49 log units) above, within the range that was stated.
By their numbers in this assay, from the lowest: compound 1; then compounds 4 and 2 (each within the scatter of the next); then compound 3.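

At this position, a saturated chain carbon bound to an oxygen on an aromatic ring, pyridin-2-yl in place of benzyl gives an 8.3-fold lower number from compound 3 to compound 4 (0.92 log units; beyond the scatter) in this assay and recovers what the longer phenethyl ether lost. Pyridin-2-yl in place of ethyl gives a 1.3-fold lower number from compound 2 to compound 4 (0.12 log units; within the scatter) on the same read-out, so the two groups are not separated here. No evidence bears on why the number moves.

Open, from the compounds shown here alone, is whether the ring nitrogen matters in itself, which pyridin-3-yl or pyridin-4-yl on the same carbon would test. Also open, going by these compounds, is how much of the far lower number of compound 1 belongs to its benzyl ether and how much to its different amide.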